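This account rests on a few compounds, and the source may have more. Where it says the series, first, only, none or still open, it means among the compounds named here.

Compound 3 `COc1ccc(C2Nc3ccccc3C(=O)N2Cc2ccccc2)cc1CSc1ccc(NC(C)=O)cc1` gives the largest maximal response of the three measured compounds in a functional assay on HEK-EM293 cells for agonist activity at Thyrotropin receptor (Homo sapiens), read by ELISA and cAMP accumulation, with a stated time of 1 h (a lower number here means a smaller maximal response, a higher number a larger maximal response), at 95.7%. Compound 1 `COc1ccc(C2Nc3ccccc3C(=O)N2Cc2ccccc2)cc1COc1cccc(NC(C)=O)c1` gives 24.8%, and compound 2 `COc1ccc(C2Nc3ccccc3C(=O)N2Cc2ccccc2)cc1COc1cccc(F)c1` gives 7.4%; the step of a number 17.4 percentage points lower from compound 1 to compound 2 (beyond the scatter) is modest, while a number 70.9 percentage points higher from compound 1 to compound 3 (beyond the scatter) and a number 88.3 percentage points higher from compound 2 to compound 3 (beyond the scatter) are large. Compound 4 `COc1ccc(C2Nc3cccc(O)c3C(=O)N2Cc2ccccc2)cc1CSc1ccc(NC(C)=O)cc1` differs from compound 3 by hydroxy in place of hydrogen on an aromatic carbon, placed on the shared core rather than on the variable side chain. For the measured compounds named here, none of the measured steps touches this part of the molecule, so none bears directly on the change, and no step beyond the scatter is expected in this assay from compound 3 to compound 4. Compound 4 is therefore estimated at 88%, with a range from 60% to 105%, an expected step of a number 7.7 percentage points lower from compound 3 to compound 4 (within the scatter).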

Compound 4, largest response reached (Emax), in percent of the reference or control that the assay uses: 69.6%
The estimate for compound 4 lay 18.4 percentage points above the measured number; the measured number falls inside the stated range.
By their numbers in this assay, from the lowest: compound 2; then compound 1; then compound 4; then compound 3.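

In this assay, for the compounds shown here, the earlier steps all changed the side chain, whereas hydroxy in place of hydrogen on this aromatic carbon of the shared core gives a number 26.1 percentage points lower from compound 3 to compound 4 (beyond the scatter) and so shows that the maximal response also depends on the core. A single added hydroxy at this position, ortho to a fused ring, is enough to produce a step beyond the scatter. Nothing given here bears on the reason for this drop.

From the compounds shown here alone, it remains open whether a methoxy, an amine or a fluorine at this carbon would lower the response in the same way.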